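This account rests on a few compounds, and the source may have more. Where it says the series, first, only, none or still open, it means among the compounds named here.

Measured so far:
- compound 1, `CCCCCNc1ncnc2c1ncn2[C@@H]1O[C@H](CO)[C@@H](O)[C@H]1O`, 13500 nM
- compound 2, `OC[C@H]1O[C@@H](n2cnc3c(OCc4ccccc4)ncnc32)[C@H](O)[C@@H]1O`, 2090 nM
- compound 3, `OC[C@H]1O[C@@H](n2cnc3c(Sc4ccccc4)ncnc32)[C@H](O)[C@@H]1O`, 91200 nM

All three share the same sugar-bearing core and differ only in the group carried on one aromatic carbon. In an assay on isolated protein for binding affinity to Equilibrative nucleoside transporter 1 (Homo sapiens) (on this read-out higher numbers stand for weaker inhibition and lower numbers for stronger inhibition), compound 3 gives the highest number of the three, and both gaps to it are beyond the scatter: a 6.8-fold higher number from compound 1 to compound 3 (0.83 log units; beyond the scatter) and a 44-fold higher number from compound 2 to compound 3 (1.64 log units; beyond the scatter). Compound 2, with benzyloxy, gives the lowest number, and a 6.5-fold lower number from compound 1 to compound 2 (0.81 log units; beyond the scatter).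

Compound 4, `OC[C@H]1O[C@@H](n2cnc3c(CSc4ccccc4Br)ncnc32)[C@H](O)[C@@H]1O`, is not yet measured. It differs from compound 3 in one place: ((2-bromophenyl)sulfanyl)methyl in place of phenylsulfanyl on an aromatic carbon. Among the compounds with values here, no measured pair shows this exact change, so the expectation rests on the surrounding steps. Compound 3 with phenylsulfanyl stands worst; compound 2, whose benzyloxy places its ring one atom further from the core, stands best, and the two are separated by a 44-fold higher number from compound 2 to compound 3 (1.64 log units; beyond the scatter). Compound 4 likewise places its ring further out than compound 3 does, so a move downward is expected, though the bromine and the sulfur make the analogy loose. The expected step is a 6.1-fold lower number from compound 3 to compound 4 (0.78 log units; beyond the scatter), a modest improvement rather than a return to the level of compound 2.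

For compound 4 in this assay the estimate is 15000 nM, with a range from 3000 nM to 70000 nM.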

Compound 4, half-maximal inhibitory concentration: 2400 nM
Compound 4: middle estimate off by 6.3-fold (0.80 log units), on the high side, outside the stated range (below it).
By their numbers in this assay, from the lowest: compounds 2 and 4 (each within the scatter of the next); then compound 1; then compound 3.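

In this assay, a sulfur in the group at this position does not by itself go with a high number: there is a 38-fold lower number from compound 3 to compound 4 (1.58 log units; beyond the scatter) when ((2-bromophenyl)sulfanyl)methyl replaces phenylsulfanyl, even though both groups hold a sulfur and one six-membered aromatic ring. Compound 4 also reaches the level of the benzyloxy compound, with a 1.1-fold higher number from compound 2 to compound 4 (0.06 log units; within the scatter) inside the scatter, and it differs from the pentylamino compound in the same direction as benzyloxy does, with a 5.6-fold lower number from compound 1 to compound 4 (0.75 log units; beyond the scatter) alongside a 6.5-fold lower number from compound 1 to compound 2 (0.81 log units; beyond the scatter) for the earlier group. Nothing measured beyond these numbers accounts for the size of these steps.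

On these data alone, what stays open is how much of the step from compound 3 belongs to the extra carbon in the link and how much to the bromine, a question that the plain (phenylsulfanyl)methyl group, with the extra carbon and no bromine, would separate. Also open, as far as these compounds go, is how this position responds to a group of a different kind, such as a carboxylic acid or an amine at the end of a longer chain.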